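The source may hold more compounds than are shown below. What is called first, only, known or untested is meant among the compounds shown, and "the series" means these compounds.

Three related compounds have been tested in an ADME assay on Vero cells (Chlorocebus sabaeus) for cytotoxicity, read by resazurin assay, with a stated time of 3 days; on this read-out lower numbers stand for stronger inhibition and higher numbers for weaker inhibition. Compound 1 `CCCCCC(=O)Nc1cc2nc(C3CCCCC3)[nH]c2cc1N1CCCC1` gives > 100 ug/mL in this assay, which is a limit of the measurement rather than a number. Compound 2 `CCCNC(=O)Nc1cc2nc(C3CCCCC3)[nH]c2cc1N1CCCC1` gives > 100 ug/mL, also a limit. Compound 3 `CCCOCC(=O)Nc1cc2nc(C3CCCCC3)[nH]c2cc1N(CC)CC` gives > 100 ug/mL, again a limit. Because every value sits at the limit of > 100 ug/mL in this assay, at which 3 of the 3 values shown sit, compound 3 stands exactly where its two companions stand, and no ordering among the three can be read. The step that the two limits leave unreadable from compound 1 to compound 2 is likewise unreadable, as both of its ends are limits.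

The next compound, compound 4 `CCCOCC(=O)Nc1cc2nc(C3CCCCC3)[nH]c2cc1N1CCCC1`, differs from compound 3 in one place: pyrrolidin-1-yl in place of diethylamino on an aromatic carbon. For the measured compounds named here, no measured step covers this exchange; the only measured step changes a different part of the molecule, and even its size could not be read. The expectation is therefore that compound 4 will behave like the three measured compounds, with a step that the limit leaves unreadable from compound 3 to compound 4 no larger than the scatter. Compound 4 is estimated at 150 ug/mL, with a range from 80 ug/mL to 400 ug/mL, and most likely it will again be reported only as a limit.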

Compound 4, half-maximal inhibitory concentration: > 100 ug/mL
Compound 4 ended at the assay's limit; the forecaster's own chance of this, stated with the estimate: 85%; the middle value does not contradict the limit.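

No step can be read between compound 4 and compound 1, compound 2 or compound 3, because each of these values is a limit and not a number: the limit of > 100 ug/mL in this assay, at which 4 of the 4 values shown sit.

The compounds shown leave open what each true value is, and whether pyrrolidin-1-yl in place of diethylamino, or any change to the chain on the carbonyl, shifts the read-out at all.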